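Cytotoxicity limits under a trifluoromethyl to trifluoromethoxy swap

A few compounds are considered here, and "the series" means these few. Any claim that something is new, unique, unknown or untested is made for them only; others in the source may bear on it.

All three measured compounds were run in an ADME assay on MRC5 cells (Homo sapiens) for cytotoxicity, read by fluorescence, with a stated time of 72 h; a higher number here means a weaker inhibitor, a lower number a stronger inhibitor.
Compound 1 `CC1(COc2ccc(OC(F)(F)F)cc2)Cn2cc([N+](=O)[O-])nc2O1`: > 64000 nM, a limit of the assay.
Compound 2 `CC1(COc2ccc(C(F)(F)F)cc2)Cn2cc([N+](=O)[O-])nc2O1`: > 64000 nM, a limit of the assay.
Compound 3 `O=[N+]([O-])c1cn2c(n1)OC(COc1ccc(-c3ccc(C(F)(F)F)cc3)nc1)C2`: > 64000 nM, a limit of the assay.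

In this assay the change trifluoromethoxy in place of trifluoromethyl on an aromatic carbon gives a step that the two limits leave unreadable from compound 2 to compound 1. How the core of compound 2 differs from the core of compound 3 is not broken down here. Compound 4 `O=[N+]([O-])c1cn2c(n1)OC(COc1ccc(-c3ccc(OC(F)(F)F)cc3)nc1)C2` is not yet measured; it carries the same change, (trifluoromethoxy in place of trifluoromethyl on an aromatic carbon), on the core of compound 3. Because (the limit of > 64000 nM in this assay, at which 3 of the 3 values shown sit), the step that the limit leaves unreadable from compound 3 to compound 4 is expected to be small or unreadable for compound 4. Compound 4 is therefore estimated at 100000 nM in this assay, most likely again as a limit rather than a number.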

Compound 4, half-maximal inhibitory concentration: > 64000 nM
Compound 4: no number, only a limit; the forecaster's own chance of this, stated with the estimate: 85%; the middle value lies beyond the limit too.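

In this assay compound 4 gives > 64000 nM, a limit and not a number, so no step can be read from compound 3 to compound 4. The compounds shown leave open what size the trifluoromethoxy for trifluoromethyl change has in this assay.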